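This account rests on a few compounds, and the source may have more. Where it says the series, first, only, none or still open, it means among the compounds named here.

Measured in an assay on CHO cells for agonist activity at Free fatty acid receptor 1 (Homo sapiens), read by luminescence, with a stated time of 20 s, in the presence of a further agent that is not named here; a higher number here means that more compound is needed for the effect, a lower number that less compound is needed:
Compound 1, `Cc1cc(Cl)ccc1-c1cccc(COc2ccc([C@H](CC(=O)O)c3nccn3C)cc2)c1C`, gives 23000 nM.
Compound 2, `Cc1c(Cl)cccc1-c1cccc(COc2ccc([C@H](CC(=O)O)c3nccn3C)cc2)c1`, gives 22000 nM.
Compound 3, `Cn1ccnc1[C@@H](CC(=O)O)c1ccc(OCc2cccc(-c3ccc(Cl)cc3Cl)c2)cc1`, gives 30000 nM.

The numbers for compound 1, compound 2 and compound 3 lie within the scatter of one another, so compound 3 stands together with the other two rather than apart from them. Compound 4, `Cc1cccc(C)c1-c1cccc(COc2ccc([C@H](CC(=O)O)c3nccn3C)cc2)c1`, differs from compound 3 by 2,6-dimethylphenyl in place of 2,4-dichlorophenyl on an aromatic carbon. Going by the values given here, the one measured step at the same place, a 1.4-fold higher number from compound 2 to compound 3 (0.13 log units; within the scatter), is within the scatter, and the three measured compounds, which differ only in this aryl group, give numbers within the scatter of one another. A step beyond the scatter in this assay is therefore not expected from compound 3 to compound 4, and the estimated step is a 1.2-fold lower number from compound 3 to compound 4 (0.08 log units; within the scatter). Compound 4 is expected to give about 25000 nM in this assay. The expected range for compound 4 runs from 8000 nM to 75000 nM.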

Compound 4, half-maximal effective concentration: 29000 nM
Estimate against measurement, compound 4: 1.2-fold (0.06 log units) below, within the range that was stated.
By their numbers in this assay, from the lowest: compounds 2, 1, 4 and 3 (each within the scatter of the next).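

With 2,6-dimethylphenyl in place of 2,4-dichlorophenyl, this assay shows a 1.0-fold lower number from compound 3 to compound 4 (0.01 log units; within the scatter), and with it in place of 3-chloro-2-methylphenyl, a 1.3-fold higher number from compound 2 to compound 4 (0.12 log units; within the scatter). An aryl group carrying only carbon substituents therefore stands with the chlorine-bearing ones, so chlorine is not required at this position for a number of this size. Nothing available explains why these aryl groups give matching numbers.

As far as these compounds go, whether a non-aryl group at this aromatic carbon, such as an amine, a carboxylic acid or a longer alkyl chain, would give a step beyond the scatter remains open.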